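Series notes: furan-2-yl in place of 3-cyanophenyl

A few compounds are considered here, and "the series" means these few. Any claim that something is new, unique, unknown or untested is made for them only; others in the source may bear on it.

Compound 1 `Nc1nc(-c2cccc(CO)c2)nc2sc(-c3ccccc3)nc12` gives 32 nM in an assay on CHO cells for displacement of a labelled ligand from adenosine receptor A1 (Homo sapiens), read by scintillation counting, with a stated time of 3 h; a higher number here means a weaker inhibitor, a lower number a stronger inhibitor.
Compound 2 `N#Cc1cccc(-c2nc(N)c3nc(-c4ccccc4)sc3n2)c1` gives 594 nM in this assay.

Compound 2 stands highest of the two numbers; its nearest neighbour is compound 1, with the step of a 19-fold higher number from compound 1 to compound 2 (1.27 log units; beyond the scatter). Compound 3 `Nc1nc(-c2ccco2)nc2sc(-c3ccccc3)nc12` carries furan-2-yl in place of 3-cyanophenyl on an aromatic carbon. Going by the values given here, no measured step exchanges these two groups, and the single step recorded, a 19-fold higher number from compound 1 to compound 2 (1.27 log units; beyond the scatter), concerns a different substituent, so it guides only loosely. Compound 3 is expected to move back toward the lower number of compound 1, a step of a 5.9-fold lower number from compound 2 to compound 3 (0.77 log units; beyond the scatter), and is estimated at 100 nM with a range from 25 nM to 400 nM.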

Compound 3, inhibition constant: 67 nM
Beside the measured number, compound 3's estimate is 1.5-fold (0.17 log units) above it; low and high end bracket the measured number.
By their numbers in this assay, from the lowest: compound 1; then compound 3; then compound 2.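

With an 8.9-fold lower number from compound 2 to compound 3 (0.95 log units; beyond the scatter) in this assay this position, between two ring nitrogen atoms, keeps a low number without a six-membered aromatic ring. With a 2.1-fold higher number from compound 1 to compound 3 (0.32 log units; beyond the scatter) furan-2-yl does not match 3-(hydroxymethyl)phenyl, so compound 3 falls between compound 1 and compound 2 in number. No available evidence explains either step.
On these data alone, whether thiophen-2-yl or pyridin-3-yl would behave like furan-2-yl stays open. Also open, as far as these compounds go, is how a carboxylic acid or an aminomethyl group in place of the hydroxymethyl on the phenyl ring would compare with compound 1.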